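The compounds below may be only part of what the source reports. "The series", "measured", "known", "first", "only" and "open" are said of these compounds alone.

Series notes. Compound 1 `CC(C)(C)c1ccc(CO/N=C/c2c(-c3ccc4ccccc4c3)nc3occn23)cc1` stands highest of the two numbers in an assay on HepG2 cells for agonist activity at nuclear receptor subfamily 1 group I member 3 (Homo sapiens), read by a luciferase reporter, with a stated time of 23 h (a lower number here means that less compound is needed, a higher number that more compound is needed for the effect), giving 7900 nM. Compound 2 `Clc1ccc(CO/N=C/c2c(-c3ccccc3)nc3sccn23)cc1Cl` differs from compound 1 in several places at once; in this assay compound 2 gives 580 nM. Compound 3 `Fc1c(F)c(F)c(CO/N=C/c2c(-c3ccc4ccccc4c3)nc3occn23)c(F)c1F` is not yet measured; it differs from compound 1 by 2,3,4,5,6-pentafluorophenyl in place of 4-(tert-butyl)phenyl on a saturated chain carbon bound to an oxygen on an unsaturated carbon. Among the measured compounds shown here, no pair of measured compounds isolates this change, and compound 2 carries its halogenated ring on a different core, so its value gives no direct guide. A modest step toward a lower number is expected, a 2.0-fold lower number from compound 1 to compound 3 (0.30 log units; within the scatter). Compound 3 is estimated at 4000 nM, with a range of 1000 nM to 16000 nM.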

Compound 3, half-maximal effective concentration: 1700 nM
Estimate against measurement, compound 3: 2.4-fold (0.37 log units) above; measured number inside the range.
By their numbers in this assay, from the lowest: compound 2; then compound 3; then compound 1.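

In this assay, among the compounds shown here, the group on a saturated chain carbon bound to an oxygen on an unsaturated carbon clearly affects the result: 2,3,4,5,6-pentafluorophenyl in place of 4-(tert-butyl)phenyl gives a 4.6-fold lower number from compound 1 to compound 3 (0.67 log units; beyond the scatter) and is the first single-place step. Nothing measured here accounts for this step.
Steps to compound 2 cannot be read, as it differs in several places. The compounds shown do not separate loss of the tert-butyl group from gain of the fluorines, and a 4-fluorophenyl or 4-methoxyphenyl group at this position remains open.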